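Aryl exchange on the aromatic nitrogen, compound 3 to compound 4

A few compounds are considered here, and "the series" means these few. Any claim that something is new, unique, unknown or untested is made for them only; others in the source may bear on it.

Compound 3 `CCOC(=O)C1=Cc2ccccc2OC1(OCc1cn(-c2ccc(F)c([N+](=O)[O-])c2)nn1)C(F)(F)F` gives 15600 nM in a functional assay on HeLa cells (Homo sapiens) for inhibition, read by MTT assay, with a stated time of 24 h (on this read-out lower numbers stand for stronger inhibition and higher numbers for weaker inhibition), and so holds the lowest of the three numbers in hand. Compound 1 `CCOC(=O)C1=Cc2ccccc2OC1(OCc1cn(-c2ccc(C)cc2)nn1)C(F)(F)F` gives 25100 nM, and the step of a 1.6-fold lower number from compound 1 to compound 3 (0.21 log units; within the scatter) keeps the two within the scatter. Among the compounds with values here, compound 2 `CCOC(=O)C1=Cc2ccccc2OC1(OCc1cn(CC(=O)Nc2ccc(C)cc2)nn1)C(F)(F)F` gives 67400 nM; the step of a 4.3-fold lower number from compound 2 to compound 3 (0.64 log units; beyond the scatter) is the one gap from compound 3 that clears the scatter, and a 2.7-fold higher number from compound 1 to compound 2 (0.43 log units; beyond the scatter) clears it too.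

Compound 4 `CCOC(=O)C1=Cc2ccccc2OC1(OCc1cn(-c2ccc([N+](=O)[O-])cc2)nn1)C(F)(F)F` differs from compound 3 by 4-nitrophenyl in place of 4-fluoro-3-nitrophenyl on an aromatic nitrogen. Within the data shown here, the only measured step that bears directly on this change is a 1.6-fold lower number from compound 1 to compound 3 (0.21 log units; within the scatter), where one aryl group on the aromatic nitrogen replaced another and the number stayed within the scatter. The larger step of a 2.7-fold higher number from compound 1 to compound 2 (0.43 log units; beyond the scatter) replaced the aryl group with ((4-methylphenyl)carbamoyl)methyl, a different kind of change, and carries less weight here. For compound 4 a step of a 1.2-fold higher number from compound 3 to compound 4 (0.06 log units; within the scatter) is therefore expected, within the scatter. Compound 4 is estimated at 18000 nM, with a range from 8000 nM to 40000 nM.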

Compound 4, half-maximal inhibitory concentration: > 150000 nM
Compound 4 was reported as a limit; the forecaster's own chance of this, stated with the estimate: 5%; middle value at least 8.3-fold (0.92 log units) away from the limit.
By their numbers in this assay, from the lowest: compounds 3 and 1 (each within the scatter of the next); then compound 2. At a limit, above all of these: compound 4.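

The reading for compound 4 in this assay is a limit and not a number: the limit of > 150000 nM in this assay, at which 1 of the 4 values shown sits. Aryl exchange on the aromatic nitrogen is not always neutral in this series: 4-nitrophenyl in place of 4-fluoro-3-nitrophenyl gives an at least 9.6-fold higher number from compound 3 to compound 4 (0.98 log units; beyond the scatter), and nitro in place of methyl on an aromatic carbon gives an at least 5.9-fold higher number from compound 1 to compound 4 (0.77 log units; beyond the scatter). The high end of the set now belongs to an aryl group rather than to ((4-methylphenyl)carbamoyl)methyl, with an at least 2.2-fold higher number from compound 2 to compound 4 (0.34 log units; beyond the scatter).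

The compounds shown do not separate the loss of fluorine from the shift of the nitro group, as both differ together in this pair. Also open, on these data alone, is whether an amine or a carboxylic acid in place of nitro on the aryl ring would bring the number back within the measured range.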